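Swapping the Amide Aryl Group on a Pyrazole Amide Core

The compounds below may be only part of what the source reports. "The series", "measured", "known", "first", "only" and "open" are said of these compounds alone.

Compound 1 `Cc1ccc(C(=O)Nc2cc(-c3ccccc3)nn2-c2ccccc2)cc1` sits at the weaker end of the two values measured in an assay on HEK293 cells for displacement of a labelled ligand from metabotropic glutamate receptor 5 (Rattus norvegicus) (a lower number here means a stronger inhibitor, a higher number a weaker inhibitor), where compound 1 gives 780 nM. Among the compounds with values here, compound 2 `O=C(Nc1cc(-c2ccccc2)nn1-c1ccccc1)c1ccc(OC(F)(F)F)cc1` gives 265 nM in this assay, and the change a 2.9-fold lower number from compound 1 to compound 2 (0.47 log units; beyond the scatter) is the only measured step available. Compound 3 `COc1cc(OC)cc(C(=O)Nc2cc(-c3ccccc3)nn2-c2ccccc2)c1` differs from compound 1 as follows: 3,5-dimethoxyphenyl in place of 4-methylphenyl on a carbonyl carbon. That step to compound 2 bears only loosely on this larger change, so the expectation for compound 3 is a number near that of compound 1, with the estimated step of a 1.2-fold higher number from compound 1 to compound 3 (0.06 log units; within the scatter). Compound 3 is estimated at 900 nM, within 300 nM to 2700 nM.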

Compound 3, inhibition constant: > 10000 nM
Compound 3 ended at the assay's limit (the forecaster's own chance of this, stated with the estimate: 10%); middle value at least 11-fold (1.04 log units) away from the limit.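

Replacing 4-methylphenyl with 3,5-dimethoxyphenyl on the carbonyl carbon gives an at least 12-fold higher number from compound 1 to compound 3 (1.10 log units; beyond the scatter), far larger than the modest earlier step, a 2.9-fold lower number from compound 1 to compound 2 (0.47 log units; beyond the scatter). So this position does not tolerate every change of aryl group equally, and a swap here can cost most of the measurable binding. The value of compound 3 is a limit, not an exact number: the limit of > 10000 nM in this assay, at which 1 of the 3 values shown sits.

The compounds shown cannot separate the effect of adding the two methoxy groups from that of losing the methyl. Going by these compounds, how an unsubstituted phenyl, or a phenyl carrying a single methoxy group or an amine, would behave also stays open.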